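A Sulfur Ring Group Added to Compound 2

The source may report more compounds than this note shows. Statements on the series, on what has been measured and on what is new or still open speak of the compounds shown alone.

Values measured in a functional assay on A549 cells (Homo sapiens) for antiproliferative activity, read by MTT assay, with a stated time of 72 h; on this read-out lower numbers stand for stronger inhibition and higher numbers for weaker inhibition:

Compound 1 `C=C1C(=O)[C@@]23C(=O)OC[C@]4(C(=O)CCC(C)(C)[C@H]4C=O)[C@@H]2CC[C@@H]1[C@H]3O` gives 5310 nM
Compound 2 `C=C1C(=O)[C@@]23C(=O)OC[C@]4([C@@H](OC(C)=O)CCC(C)(C)[C@H]4C=O)[C@@H]2CC[C@@H]1[C@H]3O` gives 27400 nM
Compound 3 `C=C1C(=O)[C@@]23C(=O)OC[C@]4(C(=O)CCC(C)(C)[C@H]4C=O)[C@@H]2CC[C@@H]1[C@H]3OC(=O)c1ccccc1C(=O)Oc1ccc(-c2cc(=S)ss2)cc1` gives 7450 nM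

Compound 2 has the highest number of the three, which makes it the weakest inhibitor in this small set. Its gap to each of the other two lies beyond the scatter. Compound 4 `C=C1C(=O)[C@@]23C(=O)OC[C@]4([C@@H](OC(C)=O)CCC(C)(C)[C@H]4C=O)[C@@H]2CC[C@@H]1[C@H]3OC(=O)CCCCC1CCSS1` differs from compound 2 in one place: a group of 11 heavy atoms (8 carbon, 1 oxygen, 2 sulfur; one five-membered non-aromatic ring with 2 hetero atoms) in place of a hydrogen atom, on an oxygen on a saturated carbon. Going by the values given here, no measured pair shows this change on its own, so any expectation rests on indirect evidence. Compound 1 gives 5310 nM and compound 3 gives 7450 nM, two values within the scatter of each other, although only compound 3 carries a large group on the corresponding oxygen. That comparison suggests that a large group on this oxygen need not cost activity. Compound 2 also differs from both of these compounds elsewhere, so the evidence carries over only loosely. Compound 3 does hint that the added group may be tolerated, and a modest move toward a lower number is expected, with the estimated step being a 2.1-fold lower number from compound 2 to compound 4 (0.32 log units; beyond the scatter) in this assay. Compound 4 is estimated at 13000 nM, with an expected range from 4500 nM to 32000 nM.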

Compound 4, half-maximal inhibitory concentration: 19900 nM
Compound 4: middle estimate off by 1.5-fold (0.18 log units), on the low side; the range from low to high includes it.
By their numbers in this assay, from the lowest: compounds 1 and 3 (each within the scatter of the next); then compounds 4 and 2 (each within the scatter of the next).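

In this assay, putting the group of 11 heavy atoms in place of the hydrogen on this oxygen on a saturated carbon gives a 1.4-fold lower number from compound 2 to compound 4 (0.14 log units; within the scatter) and so leaves the two compounds indistinguishable. Going by these compounds alone, this is the first direct reading at this position, and it shows that the hydrogen can be replaced by a much larger group carrying a five-membered non-aromatic ring with two sulfur atoms without a loss of activity that stands out from the scatter. It shows equally that this change brings no gain that stands out from the scatter, and nothing measured here explains why so large an addition makes so little difference.

Going by these compounds, because this is a single change on a single parent, it remains open whether a plain carbon chain without the sulfur ring, a chain ending in an amine or a carboxylic acid, or a shorter ester would also leave the number in the same region. On these data alone, it is also open whether the same sulfur ring group would give a similar result on the core of compound 1, which carries a ketone where compound 2 carries an acetate.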